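A few compounds are considered here, and "the series" means these few. Any claim that something is new, unique, unknown or untested is made for them only; others in the source may bear on it.

Measured compounds:
- compound 1 `Cc1cccc(NC(=O)CN2CCC(c3ccc(O)cc3)CC2)c1`: 70 nM
- compound 2 `O=C(CN1CCC(c2cccc[n+]2[O-])CC1)Nc1ccccc1F`: 270 nM
- compound 3 `CSc1cccc(NC(=O)CN2CCC(c3cccc[n+]3[O-])CC2)c1`: 100 nM

In a functional assay on HEK293 cells for agonist activity at D(4) dopamine receptor (Homo sapiens), read by FLIPR (on this read-out higher numbers stand for an effect only at larger amounts of compound and lower numbers for an effect already at smaller amounts), compound 1 gives the lowest of the three numbers. Its nearest neighbour is compound 3 at 100 nM, a gap that stays within the usual scatter, so the two cannot be ordered; compound 2 at 270 nM lies furthest away and that gap is beyond the scatter.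

Compound 4 `Cc1cccc(NC(=O)CN2CCC(c3ccccc3C#N)CC2)c1` differs from compound 1 in one place: 2-cyanophenyl in place of 4-hydroxyphenyl on a saturated ring carbon. For the measured compounds named here, the only measured step, a 2.7-fold lower number from compound 2 to compound 3 (0.43 log units; beyond the scatter), concerns the group on the amide-type nitrogen and leaves the saturated ring carbon untouched, so it does not bear on the change from compound 1 to compound 4. Going by the values given here, compounds 2 and 3 carry a different group on that saturated ring carbon than compound 1, but no single-change step connects them to compound 1, and their values show only that all three sit within a modest span of this assay.

Among the compounds with values here, with no direct precedent, the direction of the change is open, and a modest upward step with wide uncertainty is expected: a 2.1-fold higher number from compound 1 to compound 4 (0.33 log units; beyond the scatter). Compound 4 is therefore estimated at 150 nM, with a range from 40 nM to 600 nM.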

Compound 4, half-maximal effective concentration: 8 nM
Beside the measured number, compound 4's estimate is 19-fold (1.27 log units) above it, outside the stated range (below it).
By their numbers in this assay, from the lowest: compound 4; then compounds 1 and 3 (each within the scatter of the next); then compound 2.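

In this assay the saturated ring carbon of the shared core proves to be a place where the group matters: 2-cyanophenyl in place of 4-hydroxyphenyl gives an 8.8-fold lower number from compound 1 to compound 4 (0.94 log units; beyond the scatter). For the compounds shown here, the earlier single-change step, a 2.7-fold lower number from compound 2 to compound 3 (0.43 log units; beyond the scatter), concerned only the group on the amide-type nitrogen, so this is the first step showing that the number also responds to a change on the saturated ring carbon, although this one step swaps the whole aryl group and does not separate the loss of the hydroxyl from the gain of the nitrile. Nothing among the data shown offers an explanation for the size of this step.

The compounds shown leave open which feature of the entering group carries the step, since a plain phenyl, a 4-cyanophenyl or a 2-hydroxyphenyl on the same carbon would be needed to tell the identity of the substituent from its place on the aromatic ring. They also leave open whether 2-cyanophenyl would give a similar step with 2-fluorophenyl or 3-(methylsulfanyl)phenyl on the amide-type nitrogen.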